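Cyclohexyl for methoxyphenyl on the ring nitrogen, second core

The source may report more compounds than this note shows. Statements on the series, on what has been measured and on what is new or still open speak of the compounds shown alone.

Measured so far:
Compound 1 `COc1cccc(N2C(=O)COc3ccc(-c4cnc(OC)c(NS(=O)(=O)c5ccc(F)cc5)c4)cc32)c1` reports a limit of the assay in a functional assay on HeLa cells (Homo sapiens) for antiproliferative activity, read by MTT assay, with a stated time of 72 h (on this read-out higher numbers stand for weaker inhibition and lower numbers for stronger inhibition), > 40000 nM.
Compound 2 `COc1ncc(-c2ccc3c(c2)N(C2CCCCC2)C(=O)CO3)cc1NS(=O)(=O)c1ccc(F)cc1` gives 6100 nM in this assay.
Compound 3 `COc1cccc(N2C(=O)COc3ccc(-c4cnc5ccccc5c4)cc32)c1` gives 11400 nM in this assay.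

Compound 1 and compound 2 share one core and differ in a single place: cyclohexyl in place of 3-methoxyphenyl on an amide-type nitrogen in a ring. The step is an at least 6.5-fold lower number from compound 1 to compound 2 (0.81 log units; beyond the scatter). Its size is open at the upper end, because compound 1 sits at the limit of > 40000 nM in this assay, at which 1 of the 3 values shown sits.

Compound 3 carries the 3-methoxyphenyl on the same kind of ring nitrogen but on another core; the difference between the two cores is not broken down here. Compound 3 and compound 2 lie within the scatter of each other, so no order between them is claimed.

Compound 4 `O=C1COc2ccc(-c3cnc4ccccc4c3)cc2N1C1CCCCC1`, not yet measured, is compound 3 with the same change applied: cyclohexyl in place of 3-methoxyphenyl on an amide-type nitrogen in a ring. The place is described in the same words on both cores, so this is the same change, seen once so far. Whether a change on one core carries over to another cannot be read from two compounds, and compound 1 gives only a limit, so the transfer is taken with caution.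

For compound 4 a step of a 5.7-fold lower number from compound 3 to compound 4 (0.76 log units; beyond the scatter) is expected in this assay, resting on an at least 6.5-fold lower number from compound 1 to compound 2 (0.81 log units; beyond the scatter) and on the starting value of compound 3, 11400 nM.
Compound 4 is estimated at 2000 nM.
Compound 4 is expected to fall between 500 nM and 8000 nM.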

Compound 4, half-maximal inhibitory concentration: 19700 nM
Beside the measured number, compound 4's estimate is 9.9-fold (0.99 log units) below it; the measured number lies above the stated range.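

On the core of compound 3, in this assay, cyclohexyl in place of 3-methoxyphenyl gives a 1.7-fold higher number from compound 3 to compound 4 (0.24 log units; within the scatter), which leaves that pair without an order. The change therefore does not carry over in size from the core of compound 1 to the core of compound 3: the same change on two cores in this assay, an at least 6.5-fold lower number (0.81 log units; beyond the scatter) from compound 1 to compound 2 and a 1.7-fold higher number (0.24 log units; within the scatter) from compound 3 to compound 4, at least 11-fold (1.05 log units) apart, beyond the scatter of two such steps

As far as these compounds go, compound 1 gives > 40000 nM, which is a limit of the assay and not a number, so the size of the first step stays open at its upper end, and two pairs on two cores give no rule for any further core.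

Open, from the compounds shown here alone, is how other groups on the amide-type nitrogen in a ring would read on either core, for example methyl, a longer chain such as n-butyl, or a chain ending in an amine or a carboxylic acid. Also open, going by these compounds, is whether a further core carrying the same two groups would follow the pair on the core of compound 1, the pair on the core of compound 3, or neither.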